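Benzyloxyphenyl imines: bromo to methyl on the phenol ring

The source may report more compounds than this note shows. Statements on the series, on what has been measured and on what is new or still open speak of the compounds shown alone.

Measured compounds and their numbers:
compound 1 `Oc1ccc(/C=N/c2ccc(OCc3ccccc3)cc2)c(O)c1` gives 6780 nM
compound 2 `O=[N+]([O-])c1ccc(O)c(/C=N/c2ccc(OCc3ccccc3)cc2)c1` gives 60900 nM
compound 3 `Oc1ccc(Br)cc1/C=N/c1ccc(OCc2ccccc2)cc1` gives 31700 nM

All three are read in an assay on isolated protein for inhibition of Amine oxidase [flavin-containing] B (Homo sapiens), read by fluorescence and Amplex Red, with stated times of 15 min and 20 min; a higher number here means a weaker inhibitor, a lower number a stronger inhibitor. Compound 3 sits second highest of the three numbers; compound 2 is nearest to it, at 60900 nM, and the two lie within the scatter of each other, while compound 1 is furthest, at 6780 nM, and a 4.7-fold higher number from compound 1 to compound 3 (0.67 log units; beyond the scatter).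

The next compound, compound 4 `Cc1ccc(O)c(/C=N/c2ccc(OCc3ccccc3)cc2)c1`, has not been measured. Against compound 3 the change is methyl in place of bromo on an aromatic carbon; the group leaving and the group entering are each a single heavy atom, neither brings a donor or acceptor, and the ring is untouched.

Among the compounds with values here, two measured steps touch the same carbon. a 1.9-fold lower number from compound 2 to compound 3 (0.28 log units; within the scatter) shows that exchanging nitro for bromo at this carbon leaves this assay essentially unmoved. a 4.7-fold higher number from compound 1 to compound 3 (0.67 log units; beyond the scatter) shows a modest shift when hydroxy is replaced by bromo together with the loss of the second hydroxy. Within the data shown here, no compound carries methyl at this carbon, so the effect of methyl itself is not known from these data. Given that nitro and bromo read alike, the expectation for a 1.4-fold lower number from compound 3 to compound 4 (0.16 log units; within the scatter) is a change not beyond the scatter.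

Compound 4 is therefore estimated at 22000 nM in this assay, with a range from 7000 nM to 65000 nM.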

Compound 4, half-maximal inhibitory concentration: 24600 nM
For compound 4 the middle estimate is 1.1-fold (0.05 log units) below the measured one; measured number inside the range.
By their numbers in this assay, from the lowest: compound 1; then compounds 4, 3 and 2 (each within the scatter of the next, the first and the last beyond it).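

In this assay the step of a 1.3-fold lower number from compound 3 to compound 4 (0.11 log units; within the scatter) is within the scatter, so methyl reads like bromo at this carbon, para to a hydroxy group, and the single heavy atom can be exchanged here without a visible shift. Within the data shown here, the step of a 2.5-fold lower number from compound 2 to compound 4 (0.39 log units; beyond the scatter) is the first single exchange at this carbon to lie beyond the scatter, and although it is modest, it shows that the position is not wholly indifferent to its group even though bromo lies within the scatter of both nitro and methyl. The step of a 3.6-fold higher number from compound 1 to compound 4 (0.56 log units; beyond the scatter) keeps 2,4-dihydroxyphenyl apart from 2-hydroxy-5-methylphenyl as well as from 5-bromo-2-hydroxyphenyl, and no measurement accompanies these numbers that could account for any of them.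

From the compounds shown here alone, whether an amine, a carboxylic acid or a longer chain such as propyl at this carbon would stay with methyl and bromo, or move further from them, remains open. Also open, going by these compounds, is whether methoxy in place of the second hydroxy of compound 1 would keep that compound's number, which would indicate how much of the gap depends on the hydroxy itself.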